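The compounds below may be only part of what the source reports. "The series", "measured", "known", "first", "only" and "open" are said of these compounds alone.

Going by the values given here, compound 3 `CO/N=C(/CCN1CCN(c2ccccn2)CC1)c1ccc(Cl)cc1` gives 68% in a functional assay on HEK293 cells with D(4) dopamine receptor (Homo sapiens) as the target, read by FLIPR (a higher number here means a larger maximal response, a lower number a smaller maximal response), the lowest of the three numbers measured so far. Compound 1 `C=CCO/N=C(\CCN1CCN(c2ccccn2)CC1)c1ccccc1` gives 69%, which lies within the scatter of compound 3. Compound 2 `CO/N=C(\CCN1CCN(c2ccccn2)CC1)c1ccc(Cl)cc1` gives 87%; it shares every atom and bond with compound 3 and differs only in how one double bond is drawn, so the step of a number 19 percentage points lower from compound 2 to compound 3 (beyond the scatter) rests on configuration alone because of the fact that compounds 2 and 3 differ only in the configuration as drawn. Compound 4 `CO/N=C(/CCN1CCN(c2ccccn2)CC1)c1ccc(Cl)cc1Cl` differs from compound 3 by chloro in place of hydrogen on an aromatic carbon. Among the compounds with values here, no measured step exchanges hydrogen for chloro on this ring, so the measured steps give no guide to the size or direction of this change. The expected step of no change at the digits printed from compound 3 to compound 4 (within the scatter) is therefore none beyond the scatter. Compound 4 is estimated at 68%, with a range from 50% to 86%.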

Compound 4, largest response reached (reported as efficacy), in percent of the reference or control that the assay uses: 65%
Estimate against measurement, compound 4: 3 percentage points above, and the stated range covers the measured number.
By their numbers in this assay, from the lowest: compounds 4, 3 and 1 (each within the scatter of the next); then compound 2.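

Going from 4-chlorophenyl to 2,4-dichlorophenyl gives a number 3 percentage points lower from compound 3 to compound 4 (within the scatter) in this assay. Going by these compounds alone, this is the first reading at this position, ortho to a large group, and it shows that a second chloro group here, with the double bond drawn Z, leaves the maximal response within the scatter of compound 3. Nothing shown here explains this result.

Going by these compounds, whether a methoxy group or an amine at this position would read the same stays open. So does the effect of this chloro group with the double bond drawn E, as in compound 2.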